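Working Notes: From Compound 1 to Compound 4

The source may hold more compounds than are shown below. What is called first, only, known or untested is meant among the compounds shown, and "the series" means these compounds.

Measured so far:
compound 1 `CC1(C)Oc2ccc(C#N)cc2[C@@H](/N=C(\NC#N)NCc2ccccc2)[C@@H]1O` — 2400 nM
compound 2 `CC1(C)Oc2ccc(C#N)cc2[C@@H](NC(=O)Nc2ccccn2)[C@@H]1O` — 440 nM
compound 3 `CC1(C)Oc2ccc(C#N)cc2[C@@H](n2c(O)nc3ccccc32)[C@@H]1O` — 41000 nM

Three compounds sharing one core have been run in a functional assay (aorta) with Rattus norvegicus as the target; on this read-out lower numbers stand for stronger inhibition and higher numbers for weaker inhibition. Compound 2 gives 440 nM, compound 1 gives 2400 nM and compound 3 gives 41000 nM. Among these three, compound 1 stands second highest: its nearest neighbour is compound 2, with a lower number, and its furthest is compound 3, with a far higher number; both gaps lie beyond the usual scatter. No two of the measured compounds differ in one place only, so no single-point step can be read from them.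

The next compound, compound 4 `CC1(C)Oc2ccc(C#N)cc2[C@@H](/N=C(\NC#N)Nc2ccc(C(=O)O)cc2)[C@@H]1O`, has not yet been run in this assay. It differs from compound 1 in one place: 4-carboxyphenyl in place of benzyl on an amine nitrogen. Within the data shown here, nothing among the measured compounds tests this same change, so the expectation rests on the spread of the series and on the part of compound 1 that is kept intact.

The step expected is a 2.1-fold higher number from compound 1 to compound 4 (0.32 log units; beyond the scatter), a modest move toward a higher number, possibly not far beyond the scatter. Compound 4 is estimated at 5000 nM, with a range from 1500 nM to 20000 nM.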

Compound 4, half-maximal inhibitory concentration: > 100000 nM
Compound 4 was reported as a limit; the forecaster's own chance of this, stated with the estimate: 5%; middle value at least 20-fold (1.30 log units) away from the limit.
By their numbers in this assay, from the lowest: compound 2; then compound 1; then compound 3. At a limit, above all of these: compound 4.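

In this assay compound 4 gives > 100000 nM, which is a limit of the assay and not a number. Among these compounds, putting 4-carboxyphenyl in place of benzyl on this amine nitrogen gives an at least 41-fold higher number from compound 1 to compound 4 (1.61 log units; beyond the scatter), the first single-place step, and it shows that activity at this position depends strongly on the group it carries. Going by these compounds, the step can be read in one direction only, since its true size stays unknown past the point where the read-out stops: the limit of > 100000 nM in this assay, at which 1 of the 4 values shown sits.

The step leaves open which part of the change matters, as it replaces benzyl with a ring that carries a carboxylic acid and no longer has the benzyl carbon linking it to the nitrogen. Unsubstituted phenyl would isolate the loss of that linking carbon, while 4-carboxybenzyl or the methyl ester of the acid would isolate the contribution of the carboxylic acid, so the present pair cannot assign the loss to either part.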